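A few compounds are considered here, and "the series" means these few. Any claim that something is new, unique, unknown or untested is made for them only; others in the source may bear on it.

In a functional assay on NALM-6 cells (Homo sapiens) for cytotoxicity, read by MTT assay, with a stated time of 46 h (on this read-out higher numbers stand for weaker inhibition and lower numbers for stronger inhibition), compound 1 `O=C1/C(=C/c2ccncc2)C(c2ccccc2)Oc2ccccc21` gives 1600 nM and compound 2 `O=C1/C(=C/c2ccccc2)C(c2ccccc2)Oc2ccccc21` gives 29500 nM. For the measured compounds named here, the only measured step is an 18-fold higher number from compound 1 to compound 2 (1.27 log units; beyond the scatter). Compound 3 `Cc1ccc(/C=C2\C(=O)c3ccccc3OC2c2ccccc2)cc1` stands at > 1000000 nM, which is a limit and not a number.

The next comparison is with compound 4 `Cc1ccc(/C=C2/C(=O)c3ccccc3OC2c2ccccc2)cc1`: the two compounds have the same atoms and bonds; at least one stereo element is drawn with a configuration in one of them and without one in the other: 1 of 2 stereo elements differ; a double bond is drawn Z in compound 3 and E in compound 4. A double bond is drawn Z in compound 3 and E in compound 4, and nothing else differs. Going by the values given here, no measured step covers a change of this kind. Among the compounds with values here, the one measured step bears on it only indirectly, as it shows that the read-out can move a long way. The anchor for the expectation is compound 2 at 29500 nM, with a wide margin on either side. A large move toward a lower number is expected, an at least 50-fold lower number from compound 3 to compound 4 (1.69 log units; beyond the scatter). A further limit reading remains possible. For compound 4 the estimated value is 20000 nM, with an expected range of 3000 nM to 150000 nM.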

Compound 4, half-maximal inhibitory concentration: 51400 nM
For compound 4 the middle estimate is 2.6-fold (0.41 log units) below the measured one; measured number inside the range.
By their numbers in this assay, from the lowest: compound 1; then compounds 2 and 4 (each within the scatter of the next). At a limit, above all of these: compound 3.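

In this assay, a change in the drawn double bond alone, with nothing entering or leaving, gives an at least 19-fold lower number from compound 3 to compound 4 (1.28 log units; beyond the scatter), which is read with one caveat: the fact that one of compounds 3 and 4 is drawn with a defined configuration and the other without, at the place where they differ. Compound 3 holds a limit and not a number: the limit of > 1000000 nM in this assay, at which 1 of the 4 values shown sits. With the double bond as in compound 4, methyl in place of hydrogen on an aromatic carbon gives a 1.7-fold higher number from compound 2 to compound 4 (0.24 log units; within the scatter), whereas 4-methylphenyl in place of pyridin-4-yl gives a 32-fold higher number from compound 1 to compound 4 (1.51 log units; beyond the scatter), so compound 1 stays clearly apart from compound 4.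

Open, from the compounds shown here alone, is whether the drawn double bond weighs as much with pyridin-4-yl on the chain carbon as with 4-methylphenyl. Also open, going by these compounds, is whether pyridin-3-yl, or a phenyl carrying a carboxylic acid or an amine, would reach the number of compound 1.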